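This account rests on a few compounds, and the source may have more. Where it says the series, first, only, none or still open, it means among the compounds named here.

Measured so far in an ADME assay on HEK293 cells (Homo sapiens) for antiproliferative activity, read by MTT assay, with a stated time of 72 h; a higher number here means a weaker inhibitor, a lower number a stronger inhibitor:
- compound 1 `COc1cc(NC(C)CCCNC(=O)CCC(=O)NCCCC(C)Nc2cc(OC)cc3cccnc23)c2ncccc2c1` gives 2250 nM.
- compound 2 `COc1cc(NC(C)CCCNC(=O)/C=C/C(=O)NCCCC(C)Nc2cc(OC)cc3cccnc23)c2ncccc2c1` reports >= 100000 nM, which is a limit of the assay, not a number.

Compound 2 thus stands at the limit of >= 100000 nM in this assay, at which 1 of the 2 values shown sits; only a limit is known for it, so no numeric gap to compound 1 can be stated, beyond that compound 1 carries a number and compound 2 does not.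

Compound 3 `COc1cc(NC(C)CCCNC(=O)/C=C\C(=O)NCCCC(C)Nc2cc(OC)cc3cccnc23)c2ncccc2c1` is the next step. Against compound 2 the change is the two compounds have the same atoms and bonds; at least one stereo element is drawn with a configuration in one of them and without one in the other: 1 of 3 stereo elements differ; a double bond is drawn E in compound 2 and Z in compound 3; in words, the two compounds have the same atoms and bonds, and the one differing stereo element is the double bond, drawn E in compound 2 and Z in compound 3. Among the measured compounds shown here, no measured step of this kind exists, so the size of the effect is open in either direction.

For compound 3 the estimate is 25000 nM, between 3000 nM and 100000 nM, the expected step being an at least 4.0-fold lower number from compound 2 to compound 3 (0.60 log units; beyond the scatter), with a real chance that only a limit is again reported.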

Compound 3, half-maximal inhibitory concentration: 17500 nM
For compound 3 the middle estimate is 1.4-fold (0.15 log units) above the measured one; the measured number falls inside the stated range.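

In this assay, a change of double-bond geometry alone, with atoms and bonds the same, shifts the read-out: an at least 5.7-fold lower number from compound 2 to compound 3 (0.75 log units; beyond the scatter). Compound 2 is only a limit of the assay, so this step gives a bound and not a full size: the limit of >= 100000 nM in this assay, at which 1 of the 3 values shown sits. The comparison also rests on how the two structures are drawn, so the stereo assignment should be kept in view when reading the step: the fact that one of compounds 2 and 3 is drawn with a defined configuration and the other without, at the place where they differ

The printed values, compound 3 with 17500 nM and compound 1 with 2250 nM, do not show whether the saturated linker of compound 1 is the better reference for the double-bond pair. On these data alone, how a triple bond or a longer chain in the same linker would read remains open.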